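The compounds below may be only part of what the source reports. "The series", "measured", "known", "first", "only" and "open" are said of these compounds alone.

Compound 1 `Cc1cc(C)cc(SCc2ccc(/C=C/C(=O)Nc3ccccc3N)cc2)c1`: 3.39%
Compound 2 `Nc1ccccc1NC(=O)/C=C/c1ccc(CSc2ccc(C(F)(F)F)cn2)cc1`: 6.82%

In a functional assay on HeLa cells (Homo sapiens) for inhibition, read by CCK-8 assay, with a stated time of 72 h, tested at 8 uM (a higher number here means more inhibition of growth at the concentration tested, a lower number less inhibition of growth), compound 2 gives 6.82%, which lies within the scatter of compound 1 at 3.39%, so neither stands apart. Compound 3 `Nc1ccccc1NC(=O)/C=C/c1ccc(CSc2ccc(F)cc2)cc1` carries 4-fluorophenyl in place of 5-(trifluoromethyl)pyridin-2-yl on a sulfur. Going by the values given here, only one measured step bears on this sulfur, a number 3.4 percentage points higher from compound 1 to compound 2 (within the scatter), where 5-(trifluoromethyl)pyridin-2-yl replaced 3,5-dimethylphenyl. On that single step, no change beyond the scatter is expected in this assay. The expected step is a number 0.8 percentage points lower from compound 2 to compound 3 (within the scatter). For compound 3 the estimated value is 6%, with an expected range of 0% to 16%.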

Compound 3, percent growth inhibition at one concentration: 10.4%
The estimate for compound 3 lay 4.4 percentage points below the measured number, and the stated range covers the measured number.
By their numbers in this assay, from the lowest: compounds 1, 2 and 3 (each within the scatter of the next).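

With 4-fluorophenyl on the sulfur, this assay shows a number 3.6 percentage points higher from compound 2 to compound 3 (within the scatter) and a number 7 percentage points higher from compound 1 to compound 3 (within the scatter). The three groups on this sulfur, 3,5-dimethylphenyl, 5-(trifluoromethyl)pyridin-2-yl and 4-fluorophenyl, therefore cannot be told apart here, whether or not the ring holds a hetero atom. No measured evidence bears on why this is so. Still open, on these data alone, is whether a group of another kind on the sulfur, such as an amine-bearing ring or a carboxylic acid-bearing ring, would give a step beyond the scatter. As far as these compounds go, a longer chain in place of the saturated chain carbon is equally open.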